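The source may report more compounds than this note shows. Statements on the series, on what has been measured and on what is new or still open speak of the compounds shown alone.

Working notes on the quinolone series in an ADME assay for permeability, using PAMPA, at pH 7.4; a lower number here means that the compound crosses the layer more slowly, a higher number that the compound crosses the layer faster.

Compound 1 `COc1ccc2[nH]c(C)c(Br)c(=O)c2c1` gives 16.7 10^-6 cm/s in this assay. Compound 2 `Cc1[nH]c2ccc(Cl)cc2c(=O)c1Br` gives 87.7 10^-6 cm/s. Within the data shown here, the single change between them is chloro in place of methoxy on an aromatic carbon, and it produced a 5.3-fold higher number from compound 1 to compound 2 (0.72 log units; beyond the scatter).

Compound 3 `COc1cccc2c(=O)c(Cc3ccccc3)c(C)[nH]c12` gives 125 10^-6 cm/s. The values of compound 2 and compound 3 lie within the scatter of each other, so no order between them is claimed; compound 1, by contrast, sits beyond the scatter below compound 3. The difference between the core of compound 1 and the core of compound 3 is not broken down here.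

Compound 4 `Cc1[nH]c2c(Cl)cccc2c(=O)c1Cc1ccccc1` has not yet been measured. Relative to compound 3 the change is chloro in place of methoxy on an aromatic carbon. Among the measured compounds shown here, this is the same kind of change as the one from compound 1 to compound 2, but not the same: in compound 2 the chloro sits meta to a fused ring and para to a fused ring, whereas in compound 4 it sits ortho to a fused ring and meta to a fused ring.

For the measured compounds named here, the only precedent for this kind of change is the step from compound 1 to compound 2, which was modest and beyond the scatter. Compound 3 already stands at a high value, and a step of that full size is not expected to be repeated; a smaller rise, within or at the edge of the scatter, is expected, giving a 1.4-fold higher number from compound 3 to compound 4 (0.16 log units; within the scatter). Compound 4 is therefore estimated at 180 10^-6 cm/s, with a range from 90 10^-6 cm/s to 350 10^-6 cm/s.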

Compound 4, apparent permeability: 412 10^-6 cm/s
The estimate for compound 4 lay 2.3-fold (0.36 log units) below the measured number, and the stated range ends below it.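

In this assay, chloro in place of methoxy on an aromatic carbon gives a 3.3-fold higher number from compound 3 to compound 4 (0.52 log units; beyond the scatter), so the rise seen on the first core appears again on a second one. Both steps point the same way and cannot be told apart in size: the same change on two cores in this assay, a 5.3-fold higher number (0.72 log units; beyond the scatter) from compound 1 to compound 2 and a 3.3-fold higher number (0.52 log units; beyond the scatter) from compound 3 to compound 4, 1.6-fold (0.20 log units) apart, within the scatter of two such steps. This shows that the change carried over between these two cores, but it rests on two pairs only: it does not show that the same step would hold on any other core, and the two pairs do not separate the effect of the core from that of the place of the chloro, which differs between them.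

The compounds shown compare only chloro and methoxy on the aromatic carbon, so it remains open how this assay would respond to an amine or a carboxylic acid there. Also open, on these data alone, is whether a longer chain in that place would follow the same direction as chloro or depart from it, and whether any such group would behave alike on the core of compound 1 and the core of compound 3.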